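Replacing 3-chlorophenyl on the amide carbonyl

The compounds below may be only part of what the source reports. "The series", "measured", "known", "first", "only" and "open" are said of these compounds alone.

Of the compounds shown here, three sharing one core have been measured in an assay on MDA-MB-231 cells for binding affinity to C-X-C chemokine receptor type 4 (Homo sapiens), read by immunofluorescence and microscopy, with stated times of 10 min and 30 min; on this read-out higher numbers stand for an effect only at larger amounts of compound and lower numbers for an effect already at smaller amounts. Compound 1 `O=C(NCc1ccc(CNS(=O)(=O)c2ccccc2)cc1)c1ccc([N+](=O)[O-])cc1` gives 100 nM. Compound 2 `Cc1ccccc1C(=O)NCc1ccc(CNS(=O)(=O)c2ccccc2)cc1` gives 1 nM. Compound 3 `O=C(NCc1ccc(CNS(=O)(=O)c2ccccc2)cc1)c1cccc(Cl)c1` gives 1000 nM, the highest number of the three; its nearest neighbour is compound 1 and its furthest is compound 2, with the step of a 1000-fold higher number from compound 2 to compound 3 (3.00 log units; beyond the scatter) and the step of a 10-fold higher number from compound 1 to compound 3 (1.00 log units; beyond the scatter) both lying beyond the scatter.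

Compound 4 `Cc1ccc(C(=O)NCc2ccc(CNS(=O)(=O)c3ccccc3)cc2)cc1` is not yet measured. It differs from compound 3 in one place: 4-methylphenyl in place of 3-chlorophenyl on a carbonyl carbon.

For the measured compounds named here, two measured steps bear on this change, since both end at the 3-chlorophenyl of compound 3. The step of a 1000-fold higher number from compound 2 to compound 3 (3.00 log units; beyond the scatter) shows that exchanging 2-methylphenyl for 3-chlorophenyl raises the number by a large amount, and the step of a 10-fold higher number from compound 1 to compound 3 (1.00 log units; beyond the scatter) shows that exchanging 4-nitrophenyl for 3-chlorophenyl raises it by a modest amount. Going the other way, from 3-chlorophenyl to 4-methylphenyl, a lower number is therefore expected in this assay, though 4-methylphenyl is not the same group as the 2-methylphenyl of compound 2, so the full reversal seen there is not assumed. The expected step is a 33-fold lower number from compound 3 to compound 4 (1.52 log units; beyond the scatter). Compound 4 is estimated at 30 nM, within a range from 3 nM to 300 nM.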

Compound 4, effective concentration (reported as EC, without a stated level of effect): 100 nM
Compound 4: middle estimate off by 3.3-fold (0.52 log units), on the low side; the range from low to high includes it.
By their numbers in this assay, from the lowest: compound 2; then compounds 1 and 4 (each within the scatter of the next); then compound 3.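

The pair of compound 2 and compound 4 shows that in this assay the methyl group alone does not account for the low number of compound 2: exchanging 2-methylphenyl for 4-methylphenyl on the carbonyl carbon reverses the step (a 100-fold higher number from compound 2 to compound 4 (2.00 log units; beyond the scatter)), so the name of the ring substituent matters less here than the specific 2-methylphenyl group. Methyl and nitro on the aromatic carbon, by contrast, cannot be told apart in this assay (no change at the digits printed from compound 1 to compound 4 (within the scatter)), and 4-methylphenyl also stands clearly apart from 3-chlorophenyl (a 10-fold lower number from compound 3 to compound 4 (1.00 log units; beyond the scatter)), which leaves the two groups named with a 4 together and compound 2 well separated from them. Nothing given here explains these differences.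

On these data alone, it remains open whether the low number of compound 2 would survive a methoxy group, an ethyl chain or an amine in place of its methyl. For the compounds shown here, compound 3 is the only compound here that carries chlorine, so the effect of that atom cannot be separated from the effect of where it sits on the ring.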